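Cyclohexyl Ester in Place of Isobutyl on the Shared Core

The source may hold more compounds than are shown below. What is called first, only, known or untested is meant among the compounds shown, and "the series" means these compounds.

Three compounds share one core and differ only in their ester groups. In an assay on isolated protein for antagonist activity at Voltage-dependent L-type calcium channel subunit alpha-1C (Cavia porcellus), with a stated time of 15 min (on this read-out lower numbers stand for stronger inhibition and higher numbers for weaker inhibition), compound 1 `CC1=C(C(=O)OCC(C)C)C(c2csc(-c3ccc(Cl)cc3)n2)C(C(=O)OCC(C)C)=C(C)N1` gives 24900 nM, compound 2 `CCOC(=O)C1=C(C)NC(C)=C(C(=O)OC)C1c1csc(-c2ccc(Cl)cc2)n1` gives 22000 nM, and compound 3 `CCOC(=O)C1=C(C)NC(C)=C(C(=O)OCC(C)C)C1c1csc(-c2ccc(Cl)cc2)n1` gives 15400 nM. Compound 3 holds the lowest of the three numbers, yet its gaps to the other two are within the scatter: a 1.6-fold lower number from compound 1 to compound 3 (0.21 log units; within the scatter) and a 1.4-fold lower number from compound 2 to compound 3 (0.15 log units; within the scatter). Compound 4 `CCOC(=O)C1=C(C)NC(C)=C(C(=O)OC2CCCCC2)C1c1csc(-c2ccc(Cl)cc2)n1` has not been measured; it differs from compound 3 by cyclohexyl in place of isobutyl on an oxygen next to a carbonyl group. Among the compounds with values here, the two measured steps both change the group on that same ester oxygen, and neither moved the number beyond the scatter, so they are the steps that bear on this change. Within the data shown here, the data hold no example of a ring entering at this place. The author therefore expects no step beyond the scatter in this assay, a 1.2-fold lower number from compound 3 to compound 4 (0.07 log units; within the scatter). Compound 4 is estimated at 13000 nM, with a range from 5000 nM to 35000 nM.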

Compound 4, half-maximal inhibitory concentration: 100000 nM
The estimate for compound 4 lay 7.7-fold (0.89 log units) below the measured number; the whole stated range lies below it.
By their numbers in this assay, from the lowest: compounds 3, 2 and 1 (each within the scatter of the next); then compound 4.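

In this assay, the change to cyclohexyl gives a 6.5-fold higher number from compound 3 to compound 4 (0.81 log units; beyond the scatter), and cyclohexyl in place of methyl on the same ester oxygen gives a 4.5-fold higher number from compound 2 to compound 4 (0.66 log units; beyond the scatter). Within the data shown here, this ester oxygen had so far carried methyl and isobutyl with no step beyond the scatter, so the number here is not indifferent to every group placed on it, and the first ring at this place is also the first change there to move the number beyond the scatter, though only modestly. Nothing in the information available accounts for this step.

The compounds shown leave open whether the ring itself or the carbon count goes with the higher number. An open n-hexyl chain and a smaller cyclopropyl ring on the same oxygen would separate those two readings.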